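Phenyl in Place of Hydrogen on a Triazine Amine

The source may hold more compounds than are shown below. What is called first, only, known or untested is meant among the compounds shown, and "the series" means these compounds.

Compound 1, `CNc1nc(NC2CCCC2)nc(NC2(C#N)CCCCC2)n1`: > 5000 nM
Compound 2, `CNc1nc(N)nc(NC2(C#N)CCCCC2)n1`: "not determined" (no result reported)

In an in vitro assay on Sf21 cells for inhibition of high affinity 3',5'-cyclic-AMP phosphodiesterase 7A (Homo sapiens) (on this read-out lower numbers stand for stronger inhibition and higher numbers for weaker inhibition), compound 1 gives > 5000 nM, which is a limit of the assay and not a number. Compound 2 has no result in this assay; its entry reads "not determined" (no result reported). Compound 2 therefore stands nowhere on the numbers shown, and the only value among the two measured compounds is the limit of compound 1, (the limit of > 5000 nM in this assay, at which 1 of the 2 values shown sits).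

Compound 3, `CNc1nc(Nc2ccccc2)nc(NC2(C#N)CCCCC2)n1`, differs from compound 2 by phenyl in place of hydrogen on a nitrogen on an aromatic ring, turning amino into anilino. For the measured compounds named here, no pair of measured compounds shows such a step, so neither its size nor its direction in this assay can be read from the data. With compound 1 sitting at a limit, (the limit of > 5000 nM in this assay, at which 1 of the 2 values shown sits), weak inhibition seems the likelier outcome. Compound 3 is expected near 8000 nM, within a range of 1000 nM to 50000 nM, with a fair chance that only a limit is reported.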

Compound 3, half-maximal inhibitory concentration: > 5000 nM
Compound 3: only a limit was reported (the forecaster's own chance of this, stated with the estimate: 65%); the middle value does not contradict the limit.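

For the compounds shown here, compound 1 and compound 3 both sit at a limit and not at a number, so no step between them can be read in this assay here: the limit of > 5000 nM in this assay, at which 2 of the 3 values shown sit. The compounds shown leave open whether phenyl in place of cyclopentyl on that nitrogen changes inhibition at all.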